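A few compounds are considered here, and "the series" means these few. Any claim that something is new, unique, unknown or untested is made for them only; others in the source may bear on it.

Among the compounds with values here, in a functional assay on DU-145 cells (Homo sapiens) for inhibition, read by trypan blue exclusion, with a stated time of 96 h (on this read-out higher numbers stand for weaker inhibition of growth and lower numbers for stronger inhibition of growth), compound 3 `Cc1ccc(S(=O)(=O)/C(=C/c2ccc(Oc3ccccc3)cc2)C(=O)c2ccc(Cl)cc2)cc1` gives 1000 nM, the lowest of the two numbers measured so far. Compound 1 `Cc1ccc(S/C(=C/c2ccc(Br)cc2)C(=O)c2ccc(Cl)cc2)cc1` gives 25000 nM. Compound 2 `Cc1ccc(S/C(=C/c2ccc(N(C)C)cc2)C(=O)c2ccc(Cl)cc2)cc1` gives > 100000 nM, which is a limit of the assay and not a number.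

The next molecule, compound 4 `Cc1ccc(S/C(=C/c2ccc(Oc3ccccc3)cc2)C(=O)c2ccc(Cl)cc2)cc1`, differs from compound 3 in one place: (4-methylphenyl)sulfanyl replaces (4-methylphenyl)sulfonyl on a double-bonded chain carbon bound to a carbonyl carbon and a double-bonded chain carbon ((4-methylphenyl)sulfanyl in place of (4-methylphenyl)sulfonyl on a double-bonded chain carbon bound to a carbonyl carbon and a double-bonded chain carbon).

Within the data shown here, no measured step makes this exact swap. Among the measured compounds shown here, the only measured step, an at least 4.0-fold higher number from compound 1 to compound 2 (0.60 log units; beyond the scatter), concerns a different place in the molecule, and its size is bounded by the limit of > 100000 nM in this assay, at which 1 of the 3 values shown sits. It shows that numbers can move well beyond the scatter among compounds carrying (4-methylphenyl)sulfanyl, but it does not set a size for this swap.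

The closer guide is compound 1, which at 25000 nM carries the entering group and has a higher number than compound 3. It also differs from compound 3 in a second place, so only part of that gap should carry over.

A rise in the number, meaning weaker inhibition of growth, is therefore expected, and the estimate is an 8.0-fold higher number from compound 3 to compound 4 (0.90 log units; beyond the scatter). Compound 4 is expected to give about 8000 nM, with an estimated range of 2000 nM to 30000 nM.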

Compound 4, concentration for 50% growth inhibition: 10000 nM
The estimate for compound 4 lay 1.3-fold (0.10 log units) below the measured number, and the stated range covers the measured number.
By their numbers in this assay, from the lowest: compound 3; then compound 4; then compound 1. At a limit, above all of these: compound 2.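

In this assay, within the data shown here, compounds 3 and 4 give the first direct reading at this position, on a double-bonded chain carbon bound to a carbonyl carbon and a double-bonded chain carbon: (4-methylphenyl)sulfanyl in place of (4-methylphenyl)sulfonyl gives a 10-fold higher number from compound 3 to compound 4 (1.00 log units; beyond the scatter), so here the sulfonyl form inhibits growth more strongly. With (4-methylphenyl)sulfanyl held fixed, phenoxy in place of bromo on an aromatic carbon gives a 2.5-fold lower number from compound 1 to compound 4 (0.40 log units; beyond the scatter), a smaller step in the direction of stronger inhibition, which shows that the aromatic carbon also matters and that each change can now be read on its own. Phenoxy in place of dimethylamino gives an at least 10-fold lower number from compound 2 to compound 4 (1.00 log units; beyond the scatter), and the size of this step rests on a value for compound 2 that is a limit of the assay and not a number: the limit of > 100000 nM in this assay, at which 1 of the 4 values shown sits.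

The sulfonyl-to-sulfanyl swap is shown only with phenoxy on the aromatic carbon, so it remains open whether it would have a similar size with bromo or dimethylamino there. Also open is how a sulfinyl group or a plain ether oxygen linking the 4-methylphenyl ring at this position would compare with the two forms shown.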